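Swapping chloro for fluoro on a thiourea series against glioblastoma cells

A few compounds are considered here, and "the series" means these few. Any claim that something is new, unique, unknown or untested is made for them only; others in the source may bear on it.

Measured compounds and their values:
- compound 1, `CC1(C)CC(NC(=S)Nc2cccc(Cl)c2)c2cc(Br)ccc2O1`, 8000 nM
- compound 2, `CC1(C)CC(NC(=S)Nc2cccc(C#N)c2)c2cc(Cl)ccc2O1`, 7000 nM
- compound 3, `CC1(C)CC(NC(=S)Nc2cccc([N+](=O)[O-])c2)c2cc(Cl)ccc2O1`, 3000 nM

All three share a thiourea linking a fused bicyclic core to a substituted phenyl ring, and all were tested in a functional assay on U-373MG ATCC cells (Homo sapiens) for inhibition, read by MTT assay, with a stated time of 72 h; on this read-out lower numbers stand for stronger inhibition and higher numbers for weaker inhibition. Compound 3 gives the lowest number of the three; compound 2 gives a higher number, and compound 1 gives a higher number still. Among the compounds with values here, the one single change measured so far, a 2.3-fold lower number from compound 2 to compound 3 (0.37 log units; beyond the scatter), concerns the substituent on the phenyl ring, not the halogen on the core.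

Compound 4, `CC1(C)CC(NC(=S)Nc2cccc([N+](=O)[O-])c2)c2cc(F)ccc2O1`, keeps the nitro group of compound 3 and differs from it only on the fused core: fluoro in place of chloro on an aromatic carbon. Within the data shown here, no measured step bears directly on a halogen swap at that position; compound 1 carries bromo there but also a different phenyl substituent, so its value cannot be assigned to either change. The expected step in this assay is therefore a small one, a 1.3-fold higher number from compound 3 to compound 4 (0.12 log units; within the scatter), with no clear direction beyond the scatter. Compound 4 is estimated at 4000 nM, ranging from 1500 nM to 10000 nM.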

Compound 4, half-maximal inhibitory concentration: 6000 nM
For compound 4 the middle estimate is 1.5-fold (0.18 log units) below the measured one, and the stated range covers the measured number.
By their numbers in this assay, from the lowest: compounds 3, 4, 2 and 1 (each within the scatter of the next, the first and the last beyond it).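

Within the data shown here, compounds 3 and 4 give the first direct reading of a halogen swap on this aromatic carbon of the core, with the nitro group on the phenyl ring held constant. In this assay, the step of a 2.0-fold higher number from compound 3 to compound 4 (0.30 log units; within the scatter) sits at the edge of the usual scatter without passing it, so this pair does not separate fluoro from chloro at this position. No measurement shown here offers an explanation for this result. 

Bromo remains unresolved, since compound 1 carries it together with a chloro group on the phenyl ring rather than the nitro group, so its number cannot be credited to the halogen alone. Also open, going by these compounds, is whether a different kind of group on this carbon, such as an amine or a methoxy group, would shift the number beyond the scatter.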